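Ethoxy for fluoro on a shared core: antiproliferation notes

The source may hold more compounds than are shown below. What is called first, only, known or untested is meant among the compounds shown, and "the series" means these compounds.

Measured compounds:
compound 1 `Cc1c(C(=O)Nc2c(F)cc(-c3cccc(F)c3)cc2F)nc2ccc(F)cc2c1O`: -0.35%
compound 2 `CCOc1ccc2nc(C(=O)Nc3c(F)cc(-c4cccc(F)c4)cc3F)c(C)c(O)c2c1`: 0.23%
compound 3 `Cc1c(C(=O)Nc2c(F)cc(-c3cccc(F)c3)cc2F)nc2ccc(F)cc2c1C(=O)O`: -0.56%

In a functional assay on A-375 cells (Homo sapiens) for antiproliferative activity, read by MTT assay, with a stated time of 24 h, tested at 0.01 ug/mL (on this read-out lower numbers stand for a weaker effect and higher numbers for a stronger effect at the one concentration tested), compound 1 gives -0.35%. Compound 2 gives 0.23% in this assay. Compound 3 gives -0.56% in this assay. All three numbers sit close to zero at the single concentration tested.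

The change from compound 1 to compound 2 is ethoxy in place of fluoro on an aromatic carbon, and it gave a number 0.6 percentage points higher from compound 1 to compound 2 (within the scatter). The cores of compound 1 and compound 3 differ by carboxy in place of hydroxy on an aromatic carbon, with a number 0.2 percentage points lower from compound 1 to compound 3 (within the scatter).

Compound 4 `CCOc1ccc2nc(C(=O)Nc3c(F)cc(-c4cccc(F)c4)cc3F)c(C)c(C(=O)O)c2c1` is unmeasured. From compound 3 it is reached by ethoxy in place of fluoro on an aromatic carbon, the same change as from compound 1 to compound 2, at a place described in the same words. Because a number 0.6 percentage points higher from compound 1 to compound 2 (within the scatter) stayed within the scatter, a step of about a number 0.6 percentage points higher from compound 3 to compound 4 (within the scatter) is expected, also within the scatter. Compound 4 is expected to give about 0%, between -5% and 5%.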

Compound 4, a percentage reported as inhibition, at one concentration (the size of the read-out at that concentration, not a potency): 0.3%
Compound 4: middle estimate off by 0.3 percentage points, on the low side; the measured number falls inside the stated range.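

In this assay, ethoxy in place of fluoro on an aromatic carbon gave a number 0.9 percentage points higher from compound 3 to compound 4 (within the scatter), and the change reads alike on both cores: the same change on two cores in this assay, a number 0.6 percentage points higher (within the scatter) from compound 1 to compound 2 and a number 0.9 percentage points higher (within the scatter) from compound 3 to compound 4, 0.3 percentage points apart, within the scatter of two such steps. Carboxy in place of hydroxy on an aromatic carbon gave a number 0.1 percentage points higher from compound 2 to compound 4 (within the scatter), with the same agreement: the same change on two cores in this assay, a number 0.2 percentage points lower (within the scatter) from compound 1 to compound 3 and a number 0.1 percentage points higher (within the scatter) from compound 2 to compound 4, 0.3 percentage points apart, within the scatter of two such steps. Among the compounds shown here, no step here lies beyond the scatter and all four numbers sit close to zero, so the series shows neither change moving the read-out on either core and gives no test of whether a real effect would carry from one core to another.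

Open, on these data alone, is how an amine or a longer alkoxy chain on that aromatic carbon would read in this assay. Also open, as far as these compounds go, is how these four compounds would read at any other concentration.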